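From a methyl branch to a cyclopropyl ring

The compounds below may be only part of what the source reports. "The series", "measured", "known", "first", "only" and "open" are said of these compounds alone.

- Compound 1 `CCn1c(C(=O)NCC(=O)O)ccc1C(CC)(CC)c1ccc(OCS(=O)(=O)c2ccccc2)c(C)c1`: 33100 nM
- Compound 2 `CCn1c(C(=O)N[C@H](C)C(=O)O)ccc1C(CC)(CC)c1ccc(OCS(=O)(=O)c2ccccc2)c(C)c1`: > 50000 nM

In a functional assay on MCF7 cells (Homo sapiens) for antiproliferative activity, read by MTT assay, with a stated time of 24 h (a lower number here means a stronger inhibitor, a higher number a weaker inhibitor), compound 1 gives 33100 nM. Compound 2 gives > 50000 nM, which is a limit of the assay and not a number. Compound 3 `CCn1c(C(=O)NC2(C(=O)O)CC2)ccc1C(CC)(CC)c1ccc(OCS(=O)(=O)c2ccccc2)c(C)c1` differs from compound 2 by 1-carboxycyclopropyl in place of 1-carboxyethyl on an amide-type nitrogen. For the measured compounds named here, the one measured step that bears on this change, a methyl in place of hydrogen on the same chain carbon, is an at least 1.5-fold higher number from compound 1 to compound 2 (0.17 log units; that floor lies within the scatter). On that evidence, no shift beyond the scatter is expected in this assay. The expected change is an at least 1.1-fold lower number from compound 2 to compound 3 (0.04 log units; that floor lies within the scatter). For compound 3 the estimated value is 45000 nM, within an expected range of 20000 nM to 100000 nM.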

Compound 3, half-maximal inhibitory concentration: 41200 nM
The estimate for compound 3 lay 1.1-fold (0.04 log units) above the measured number; measured number inside the range.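

In this assay, 1-carboxycyclopropyl in place of 1-carboxyethyl gives an at least 1.2-fold lower number from compound 2 to compound 3 (0.08 log units; that floor lies within the scatter). That step is only a floor, since the value of compound 2 is a limit of the assay and not a number: the limit of > 50000 nM in this assay, at which 1 of the 3 values shown sits.

Set against carboxymethyl, the ring gives a 1.2-fold higher number from compound 1 to compound 3 (0.10 log units; within the scatter), so this branched group yields a real number at this position, with no shift beyond the scatter.

Open, from the compounds shown here alone, is how a 1-carboxycyclobutyl group, or an amine in place of the carboxylic acid, would read on this amide-type nitrogen.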